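The source may hold more compounds than are shown below. What is called first, only, known or untested is meant among the compounds shown, and "the series" means these compounds.

In a functional assay (aorta) with Oryctolagus cuniculus as the target (a lower number here means tighter binding, a higher number weaker binding), compound 1 `Fc1ccc(C(c2ccc(F)cc2)C2CCN(CCCOc3ccc(Cl)cc3)CC2)cc1`, carrying chloro, gives 2 nM, and compound 2 `CC(C)(C)c1ccc(OCCCN2CCC(C(c3ccc(F)cc3)c3ccc(F)cc3)CC2)cc1`, carrying tert-butyl, gives 1 nM. Compound 3 `Nc1ccc(OCCCN2CCC(C(c3ccc(F)cc3)c3ccc(F)cc3)CC2)cc1`, carrying amino, gives 31.6 nM, the highest number of the three. Compound 4 `Fc1ccc(C(c2ccc(F)cc2)C2CCN(CCCOc3ccccc3)CC2)cc1` differs from compound 3 by hydrogen in place of amino on an aromatic carbon, para to a large group. For the measured compounds named here, three measured steps bear on this change. Chloro and tert-butyl stay close, with a 2.0-fold lower number from compound 1 to compound 2 (0.30 log units; within the scatter), whereas amino stands apart, with a 16-fold higher number from compound 1 to compound 3 (1.20 log units; beyond the scatter) and a 32-fold higher number from compound 2 to compound 3 (1.50 log units; beyond the scatter). Going by the values given here, no measured compound carries hydrogen at this place, so the size of the step remains uncertain. The expected step, a clearly lower number, is a 5.3-fold lower number from compound 3 to compound 4 (0.72 log units; beyond the scatter). For compound 4 the estimate is 6 nM, with an expected range of 1.5 nM to 25 nM.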

Compound 4, dissociation constant: 1.59 nM
For compound 4 the middle estimate is 3.8-fold (0.58 log units) above the measured one; measured number inside the range.
By their numbers in this assay, from the lowest: compounds 2, 4 and 1 (each within the scatter of the next); then compound 3.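

In this assay, hydrogen in place of amino recovers the tight binding seen with the other groups at this place (a 20-fold lower number from compound 3 to compound 4 (1.30 log units; beyond the scatter)). Hydrogen stays level with both tert-butyl (a 1.6-fold higher number from compound 2 to compound 4 (0.20 log units; within the scatter)) and chloro (a 1.3-fold lower number from compound 1 to compound 4 (0.10 log units; within the scatter)), so this position tolerates a bare ring carbon as well as a small or bulky group, and among these four groups only amino stands apart. Nothing measured here explains why amino differs. From the compounds shown here alone, whether a hydroxyl, a dimethylamino group or a carboxylic acid at this place would stand apart like amino or stay with the other three remains open.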